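The source may report more compounds than this note shows. Statements on the series, on what has been measured and on what is new or still open speak of the compounds shown alone.

Of the compounds shown here, three that share one core have so far been measured in a functional assay on MCF7 cells (Homo sapiens) for antiproliferative activity, read by MTT assay, with a stated time of 48 h, tested at 25 uM; on this read-out higher numbers stand for a weaker effect at the one concentration tested and lower numbers for a stronger effect. Compound 3 `OC(CCn1nc2c(Br)c(Br)c(Br)c(Br)c2n1)c1ccccc1` carries an unsubstituted phenyl, and in this assay compound 3 gives 105%. Compound 1 `OC(CCn1nc2c(Br)c(Br)c(Br)c(Br)c2n1)c1ccc(F)cc1` gives 97% in this assay, while compound 2 `COc1cccc(C(O)CCn2nc3c(Br)c(Br)c(Br)c(Br)c3n2)c1` gives 96%. Compound 3 thus holds the highest of the three numbers, yet the steps of a number 8 percentage points higher from compound 1 to compound 3 (within the scatter) and a number 9 percentage points higher from compound 2 to compound 3 (within the scatter) both lie within the scatter, so the three compounds cannot be told apart on these numbers. Compound 4 `OC(CCn1nc2c(Br)c(Br)c(Br)c(Br)c2n1)c1ccc(Cl)cc1` has not yet been measured; it differs from compound 3 by chloro in place of hydrogen on an aromatic carbon. The measured step that bears most directly on this change is a number 8 percentage points higher from compound 1 to compound 3 (within the scatter), in which fluoro rather than chloro sat on the aromatic carbon, and the step of a number 9 percentage points higher from compound 2 to compound 3 (within the scatter) with methoxy points the same way: neither halogen nor methoxy on the phenyl moved the read-out beyond the scatter. Compound 4 is therefore expected to show a number 5 percentage points lower from compound 3 to compound 4 (within the scatter), that is no step beyond the scatter. The estimate for compound 4 in this assay is 100%, with a range from 88% to 112%.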

Compound 4, a percentage reported as activity, at one concentration (the size of the read-out at that concentration, not a potency): 92%
The estimate for compound 4 lay 8 percentage points above the measured number; the range from low to high includes it.
By their numbers in this assay, from the lowest: compounds 4, 2, 1 and 3 (each within the scatter of the next, the first and the last beyond it).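

In this assay, going by these compounds alone, chloro in place of hydrogen on the aromatic carbon para to a large group gives the first step beyond the scatter, a number 13 percentage points lower from compound 3 to compound 4 (beyond the scatter), though it is only modest in size. Chloro is set apart from hydrogen alone, since a number 5 percentage points lower from compound 1 to compound 4 (within the scatter) and a number 4 percentage points lower from compound 2 to compound 4 (within the scatter) both stay within the scatter, so this position shows no separation between chloro and fluoro, nor between 4-chlorophenyl and 3-methoxyphenyl. No measurement at hand accounts for the step.

On these data alone, whether bromo or methyl on the same aromatic carbon would give a step of similar size remains open. So does the effect of an amine or a carboxylic acid at this place, or of a longer chain between the core and the phenyl.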